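This account rests on a few compounds, and the source may have more. Where it says the series, first, only, none or still open, it means among the compounds named here.

Compound 1 is `CN1Cc2ccc(OCc3ccc([N+](=O)[O-])cc3)cc2[C@@H](O)C1` and compound 2 is `CN1Cc2ccc(OCc3ccc(-c4ccc(Cl)cc4)cc3)cc2[C@@H](O)C1`. In an ADME assay on Vero cells (Chlorocebus sabaeus) for cytotoxicity, read by sulforhodamine B assay, with a stated time of 72 h (a lower number here means a stronger inhibitor, a higher number a weaker inhibitor), compound 1 reports only a limit, > 50000 nM. In this assay compound 2 gives 21700 nM. Among the measured compounds shown here, the step of an at least 2.3-fold lower number from compound 1 to compound 2 (0.36 log units; beyond the scatter) is the single measured step, and since its starting point sits at the limit of > 50000 nM in this assay, at which 1 of the 2 values shown sits, its true size is not pinned down. Among the values shown, compound 2 holds the only actual number in this assay; the other value is a limit.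

Compound 3 is `CN1Cc2ccc(OCc3ccc(-c4ccc(F)cc4)cc3)cc2[C@@H](O)C1`, and it differs from compound 2 as follows: fluoro in place of chloro on an aromatic carbon. For the measured compounds named here, no measured step exchanges one halogen for another; the step from compound 1 to compound 2 replaces a nitro with a whole 4-chlorophenyl and so bears on this change only loosely. On that basis the account expects a step of a 1.2-fold higher number from compound 2 to compound 3 (0.06 log units; within the scatter) that stays within the scatter, with no direction favoured. Compound 3 is therefore estimated at 25000 nM in this assay, with a range from 12000 nM to 50000 nM.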

Compound 3, half-maximal inhibitory concentration: 33800 nM
Beside the measured number, compound 3's estimate is 1.4-fold (0.13 log units) below it; the measured number falls inside the stated range.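

The step of a 1.6-fold higher number from compound 2 to compound 3 (0.19 log units; within the scatter) shows that, in this assay, chloro and fluoro cannot be told apart at this place, on an aromatic carbon para to a large group, so this exchange of one halogen for another gives no measurable separation between the two compounds. The comparison with the nitro compound is less firm for the fluoro compound than for the chloro compound: the step of an at least 1.4-fold lower number from compound 1 to compound 3 (0.17 log units; that floor lies within the scatter) has a floor that does not clear the scatter, while the step of an at least 2.3-fold lower number from compound 1 to compound 2 (0.36 log units; beyond the scatter) does clear it, so only compound 2 is shown to be separated from compound 1. The true size of both steps stays unknown, since compound 1 is reported only as a limit and not as a number: the limit of > 50000 nM in this assay, at which 1 of the 3 values shown sits.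

The compounds shown leave open where compound 1 actually lies and whether the 4-fluorophenyl group truly differs from nitro in this assay. They also leave open whether a group other than a halogen at the same place, such as a methoxy group, an amine or a carboxylic acid, would give a number that stands apart from those of compound 2 and compound 3.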